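From nitro to fluoro on the shared core

The source may hold more compounds than are shown below. What is called first, only, known or untested is meant among the compounds shown, and "the series" means these compounds.

Measured in an ADME assay on cells (Erythrocyte, Homo sapiens), read by hemolysis, with a stated time of 1 h; on this read-out lower numbers stand for stronger inhibition and higher numbers for weaker inhibition:
- compound 1 `CC(=NNC(=S)Nc1ccccc1F)c1ccccn1`: > 10000 nM
- compound 2 `CC(=NNC(=S)Nc1cccc([N+](=O)[O-])c1)c1ccccn1`: > 10000 nM

Compound 2 stands at > 10000 nM, which is a limit of the assay and not a number. Compound 1 gives > 10000 nM, also a limit. For the measured compounds named here, the series so far therefore amounts to one reading: the limit of > 10000 nM in this assay, at which 2 of the 2 values shown sit.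

Compound 3 `CC(=NNC(=S)Nc1cccc(F)c1)c1ccccn1` carries fluoro in place of nitro on an aromatic carbon, meta to a large group: fluoro in place of nitro on an aromatic carbon.

Going by the values given here, no measured step shows what this exchange does in this assay, so no shift beyond the scatter is expected, in either direction. The expectation leans on compound 1, which also carries fluoro and reads > 10000 nM.

The expected change is a step that the limit leaves unreadable from compound 2 to compound 3. For compound 3 the estimated value is 15000 nM, with an expected range from 6000 nM to 40000 nM.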

Compound 3, half-maximal inhibitory concentration: > 10000 nM
Compound 3 gave a limit, no number (the forecaster's own chance of this, stated with the estimate: 85%); the middle value is on the limit's open side.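

Compound 2 and compound 3 both stand at limits in this assay, so no step between them can be read: the limit of > 10000 nM in this assay, at which 3 of the 3 values shown sit.

The compounds shown leave open whether any change on the shared core gives a readable number in this assay.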